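The compounds below may be only part of what the source reports. "The series", "measured", "known", "first", "only" and "open" are said of these compounds alone.

Among the measured compounds shown here, in an assay on Sf9 cells for inhibition of mitogen-activated protein kinase kinase kinase 14 (Homo sapiens), read by ADP-Glo, with a stated time of 60 min (on this read-out higher numbers stand for weaker inhibition and lower numbers for stronger inhibition), compound 3 `Cc1nn(C(=O)C2CCC2)c(N)c1-c1ccc(Cl)c(Cl)c1` gives 2900 nM, the only actual number among the three measured compounds. Compound 1 `Cc1[nH]nc(N)c1-c1ccc(Cl)c(Cl)c1` reaches only a limit of this assay, > 100000 nM. Compound 2 `Cc1[nH]nc(N)c1-c1ccc(Br)cc1` likewise reaches only a limit, > 100000 nM. That limit is the limit of > 100000 nM in this assay, at which 2 of the 3 values shown sit. Compound 4 `CCNC(=O)n1nc(C)c(-c2ccc(Cl)c(Cl)c2)c1N` has not yet been measured; it differs from compound 3 by ethylamino in place of cyclobutyl on a carbonyl carbon. No pair of measured compounds shares a single change, so nothing shown sets the size of such a step. The step of a 1.0-fold higher number from compound 3 to compound 4 (0.01 log units; within the scatter) is expected to remain within the usual scatter of this assay. Compound 4 is accordingly estimated at 3000 nM, with a range from 800 nM to 12000 nM.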

Compound 4, half-maximal inhibitory concentration: > 100000 nM
Compound 4: a limit, no number; the forecaster's own chance of this, stated with the estimate: 15%; at least 33-fold (1.52 log units) between middle value and limit.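

In this assay, the group on the carbonyl carbon clearly matters: ethylamino in place of cyclobutyl brings an at least 34-fold higher number from compound 3 to compound 4 (1.53 log units; beyond the scatter), so a carbonyl at this position is not enough on its own. Compound 4 gives only a limit, so the full size of this step cannot be read. It now sits with most of the set: the limit of > 100000 nM in this assay, at which 3 of the 4 values shown sit.

The change removes a ring and adds a nitrogen at once, and the compounds shown do not separate these two differences. Cyclobutylamino or a propyl chain on the same carbonyl carbon would tell them apart.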